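Notes on the chain-terminus change from compound 3 to compound 4

A few compounds are considered here, and "the series" means these few. Any claim that something is new, unique, unknown or untested is made for them only; others in the source may bear on it.

Compound 3 `CCC(CC)(c1ccc(OCCCCCO)c(C)c1)c1ccc(OCC(O)C(C)(C)C)c(OCC(O)C(C)(C)C)c1` gives 67% in an assay on cells for binding affinity to vitamin D3 receptor (Homo sapiens), read by fluorescence, tested at 1 uM (a higher number here means more inhibition at the concentration tested (going by the name of the read-out), a lower number less inhibition), the second highest of the three numbers: compound 1 `CCC(CC)(c1ccc(OCC(O)CO)c(C)c1)c1ccc(OCC(O)C(C)(C)C)c(OCC(O)C(C)(C)C)c1` gives 78%, and compound 2 `CCC(CC)(c1ccc(OCCO)c(C)c1)c1ccc(OCC(O)C(C)(C)C)c(OCC(O)C(C)(C)C)c1` gives 38%. Compound 4 `CCC(CC)(c1ccc(OCCCCCCC(=O)O)c(C)c1)c1ccc(OCC(O)C(C)(C)C)c(OCC(O)C(C)(C)C)c1` differs from compound 3 by carboxymethyl in place of hydroxy on a saturated chain carbon, five bonds along the chain from an oxygen on an aromatic ring. Going by the values given here, no measured step exchanges a hydroxy for a carboxymethyl, so the nearest guidance comes from steps on the same chain: a number 29 percentage points higher from compound 2 to compound 3 (beyond the scatter), where lengthening the chain ending in hydroxy raised the read-out, while a number 11 percentage points lower from compound 1 to compound 3 (beyond the scatter) was modest. Compound 4 lengthens the chain further and ends it in an acid, a change the measured steps do not cover, so a step of uncertain direction, expected within or only modestly beyond the scatter, is estimated: a number 7 percentage points lower from compound 3 to compound 4 (within the scatter). For compound 4 a value around 60% is expected, between 40% and 80%.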

Compound 4, a percentage reported as inhibition, at one concentration (the size of the read-out at that concentration, not a potency): "not active" (no number reported)
Compound 4: no number reported; there is nothing to compare the estimate with.
By their numbers in this assay, from the lowest: compound 2; then compound 3; then compound 1.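

Going by these compounds alone, compound 4 is reported as "not active" in this assay without a number, so no step from compound 3 can be read. No supporting evidence bears on this result. The compounds shown leave open how the carboxymethyl terminus changes the read-out relative to hydroxy.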